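Working Notes: From Compound 1 to Compound 4

The source may hold more compounds than are shown below. What is called first, only, known or untested is meant among the compounds shown, and "the series" means these compounds.

Compound 1 `CCc1ccccc1N(Cc1nnc(Cc2ccccc2)o1)S(=O)(=O)c1ccc(C)cc1` gives 398 nM in a functional assay on CHO cells for antagonist activity at prostaglandin E2 receptor EP1 subtype (Homo sapiens), read by FLIPR and calcium flux (on this read-out higher numbers stand for weaker inhibition and lower numbers for stronger inhibition), and stands second highest of the three numbers; compound 3 `Cc1ccc(S(=O)(=O)N(Cc2nnc(Cc3ccccc3F)o2)c2cccc(Cl)c2C)cc1` at 631 nM sits within the scatter of it, while compound 2 `Cc1ccc(S(=O)(=O)N(Cc2nnc(Cc3ccc(N(C)C)cc3)o2)c2cccc(Cl)c2C)cc1` at 20 nM lies far below it. Within the data shown here, the one measured step at the same place, a 32-fold higher number from compound 2 to compound 3 (1.50 log units; beyond the scatter), shows that the group on the saturated chain carbon bound to an aromatic carbon can shift this assay strongly. Compound 4 `CCc1ccccc1N(Cc1nnc(COc2ccc(OC)cc2)o1)S(=O)(=O)c1ccc(C)cc1` carries 4-methoxyphenoxy in place of phenyl on a saturated chain carbon bound to an aromatic carbon. Among the measured compounds shown here, no measured pair tests 4-methoxyphenoxy itself, so direction rests on the wide spread seen in this assay. A moderate step of a 1.6-fold lower number from compound 1 to compound 4 (0.20 log units; within the scatter) is expected, and compound 4 is estimated at 250 nM, with a range from 60 nM to 1000 nM.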

Compound 4, inhibition constant: 126 nM
The estimate for compound 4 lay 2.0-fold (0.30 log units) above the measured number; low and high end bracket the measured number.
By their numbers in this assay, from the lowest: compound 2; then compound 4; then compounds 1 and 3 (each within the scatter of the next).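

In this assay, 4-methoxyphenoxy in place of phenyl gives a 3.2-fold lower number from compound 1 to compound 4 (0.50 log units; beyond the scatter), so a change at this place moves the number down on the core of compound 1, whereas the earlier step at this place, on a different background, went up. The step is modest and beyond the scatter. No supporting data explain it.

The compounds shown leave open whether the ring methoxy or the linking oxygen accounts for the step. Plain phenoxy and 4-methoxybenzyl at this place would separate the two.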